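Hydrazone aryl swap at the triazine series, pyridin-2-yl entry

This account rests on a few compounds, and the source may have more. Where it says the series, first, only, none or still open, it means among the compounds named here.

In a functional assay on SF-268 cells (Homo sapiens) for inhibition, read by sulforhodamine B assay, with a stated time of 48 h (on this read-out higher numbers stand for weaker inhibition of growth and lower numbers for stronger inhibition of growth), compound 1 `NS(=O)(=O)c1ccc(Nc2nc(N/N=C/c3ccc(C(F)(F)F)cc3)nc(Nc3ccccc3)n2)cc1` gives 3510 nM. Compound 2 `Cc1nn(-c2ccccc2)cc1/C=N/Nc1nc(Nc2ccccc2)nc(Nc2ccc(S(N)(=O)=O)cc2)n1` gives 2930 nM in this assay, and of the two numbers shown compound 2 is not set apart from compound 1: a 1.2-fold lower number from compound 1 to compound 2 (0.08 log units; within the scatter). Compound 3 `NS(=O)(=O)c1ccc(Nc2nc(N/N=C/c3ccccn3)nc(Nc3ccccc3)n2)cc1` is the next member. The change from compound 2 to compound 3 is pyridin-2-yl in place of 3-methyl-1-phenyl-1H-pyrazol-4-yl on a carbon with a double bond to nitrogen. For the measured compounds named here, the only measured step at this position is the one from compound 1 to compound 2, also an exchange of the aryl group on the carbon with a double bond to nitrogen, and it gave a 1.2-fold lower number from compound 1 to compound 2 (0.08 log units; within the scatter). Going by the values given here, with one step of that size as the only guide, no step beyond the scatter is expected in this assay for compound 3. Compound 3 is therefore estimated at 3000 nM (range 1000 nM to 9000 nM), meaning an expected step of a 1.0-fold higher number from compound 2 to compound 3 (0.01 log units; within the scatter).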

Compound 3, concentration for 50% growth inhibition: 460 nM
Compound 3: middle estimate off by 6.5-fold (0.81 log units), on the high side, outside the stated range (below it).
By their numbers in this assay, from the lowest: compound 3; then compounds 2 and 1 (each within the scatter of the next).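

In this assay, this position proves able to shift the number beyond the scatter, which the exchange between the two earlier aryl groups did not show: pyridin-2-yl gives a 6.4-fold lower number from compound 2 to compound 3 (0.80 log units; beyond the scatter) and a 7.6-fold lower number from compound 1 to compound 3 (0.88 log units; beyond the scatter). The change holds against both a 4-(trifluoromethyl)phenyl and a 3-methyl-1-phenyl-1H-pyrazol-4-yl group, so among these three compounds pyridin-2-yl stands apart, with no compound going against this. Nothing available accounts for the step.

On these data alone, it stays open whether the lower number goes with the ring nitrogen of pyridin-2-yl or with a ring that carries no further substituent. Unsubstituted phenyl and pyridin-3-yl on the same carbon with a double bond to nitrogen would separate these two readings.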